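Pyrazolyl enones: swapping the aryl ketone substituents

This account rests on a few compounds, and the source may have more. Where it says the series, first, only, none or still open, it means among the compounds named here.

Measured so far in a functional assay on SF-539 cells (Homo sapiens) for cytotoxicity, read by sulforhodamine B assay, with a stated time of 48 h, tested at 1 uM; on this read-out lower numbers stand for a stronger effect and higher numbers for a weaker effect at the one concentration tested:
compound 1 `COc1cc(-c2cc(/C=C/C(=O)c3ccc(Cl)c(Cl)c3)[nH]n2)cc(OC)c1OC` gives 88%
compound 2 `COc1ccc(-c2cc(/C=C/C(=O)c3cc(OC)c(OC)c(OC)c3)[nH]n2)cc1OC` gives 17%
compound 3 `COc1ccc(-c2cc(/C=C/C(=O)c3ccc(N)cc3)[nH]n2)cc1` gives 72%

Compound 1 stands highest of the three numbers in this assay, and both of its gaps are beyond the scatter: compound 3 sits clearly lower, compound 2 far lower still. On these three numbers compound 1 is therefore the weakest of the set. Compound 2, which carries methoxy groups rather than chlorines on the aryl ring attached to the carbonyl, is the only one of the three with a strong effect.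

Compound 4 `COc1ccc(C(=O)/C=C/c2cc(-c3cc(OC)c(OC)c(OC)c3)n[nH]2)cc1OC` is not yet measured. It differs from compound 1 in one place: 3,4-dimethoxyphenyl in place of 3,4-dichlorophenyl on a carbonyl carbon. For the measured compounds named here, no step between two measured compounds has been computed for a change of this kind, so the expectation rests on the three values alone. Since compound 2 with a methoxy-bearing ketone aryl gives 17%, the change from chlorines to methoxy groups in compound 4 is expected to move the number downward by a step beyond the scatter, a number 46 percentage points lower from compound 1 to compound 4 (beyond the scatter), though not necessarily all the way to compound 2. For compound 4 the estimate in this assay is 42%, within the range 15% to 75%.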

Compound 4, a percentage reported as activity, at one concentration (the size of the read-out at that concentration, not a potency): 67%
Beside the measured number, compound 4's estimate is 25 percentage points below it; low and high end bracket the measured number.
By their numbers in this assay, from the lowest: compound 2; then compounds 4 and 3 (each within the scatter of the next); then compound 1.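

In this assay, for the compounds shown here, 3,4-dimethoxyphenyl in place of 3,4-dichlorophenyl on a carbonyl carbon gives a number 21 percentage points lower from compound 1 to compound 4 (beyond the scatter), the first change that can be read in one place, with the rest of the structure held constant. The step shows that the number responds to the aryl group at this position, but it is modest, and with this change alone compound 4 stays at 67%, so the change does not by itself produce a strong effect; compound 2 differs from compound 4 in more than one place, and its low number cannot be assigned to this change. Nothing measured here bears on why the number moves at this position.

Still open, as far as these compounds go, is whether the step belongs to the arrival of the methoxy groups, the loss of the chlorines, or both, and whether a nitrile or a carboxylic acid on the same aryl ring would move the number further. The compounds shown also leave open how much the aryl group at the other end of the core contributes, and whether a change there would alter the size of this step.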